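Removing a chloro from a weak thiophene amine ketone

The source may hold more compounds than are shown below. What is called first, only, known or untested is meant among the compounds shown, and "the series" means these compounds.

Compound 1, `Nc1scc(-c2ccccc2F)c1C(=O)c1ccc(Cl)cc1`: 5.1
Compound 2, `Nc1scc(-c2cc(C(F)(F)F)cc(C(F)(F)F)c2)c1C(=O)c1ccc(Cl)cc1`: 5.46
Compound 3, `CCOC(=O)c1nn(-c2cccc(Cl)c2)c(=O)c2c(N)scc12`: 8.3

All three were tested in an assay on isolated protein with adenosine receptor A1 (Homo sapiens) as the target, read by ERK phosphorylation; on this read-out higher numbers stand for higher potency (the scale is a negative logarithm) and lower numbers for lower potency. Among the three numbers compound 2 stands second highest: compound 1 lies a little lower, beyond the usual scatter, while compound 3 lies far higher, well beyond it.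

The next compound, compound 4, `Nc1scc(-c2cc(C(F)(F)F)cc(C(F)(F)F)c2)c1C(=O)c1ccccc1`, has not been measured. It differs from compound 2 in one place: hydrogen in place of chloro on an aromatic carbon.

Within the data shown here, no pair measured so far isolates this change, so there is nothing in the data to set its size. A small step is expected in this assay, most likely downward or none beyond the scatter, and the step from compound 2 to compound 4 is estimated as a number 0.26 log units lower from compound 2 to compound 4 (within the scatter). Compound 4 is therefore expected to give about 5.2, within a range from 4.6 to 5.8.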

Compound 4, negative logarithm of the antagonist equilibrium constant: 5.22
Estimate against measurement, compound 4: 0.02 log units below, and the stated range covers the measured number.
By their numbers in this assay, from the lowest: compounds 1, 4 and 2 (each within the scatter of the next, the first and the last beyond it); then compound 3.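

Among these compounds, this is the first pair that isolates the chloro on the benzoyl ring. In this assay, going from 4-chlorophenyl to phenyl gives a number 0.24 log units lower from compound 2 to compound 4 (within the scatter), so with this core, removing the chloro makes no clear difference to potency. No measurement shown here offers an explanation for this result.

Still open, as far as these compounds go, is whether a larger or different group in the same place, such as an amine, a methoxy group or a carboxylic acid, would move the number beyond the scatter. Also open, from the compounds shown here alone, is whether removing the chloro from compound 1 would give the same result.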